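Two ring nitrogens lose their methyls: what oral exposure follows

This account rests on a few compounds, and the source may have more. Where it says the series, first, only, none or still open, it means among the compounds named here.

In an in vivo ADME assay on the whole organism (strain BALB/cAnNCrl) for pharmacokinetics, with Mus musculus as the target, at a dose of 10 mg/kg by the oral route (a lower number here means that a smaller share of the oral dose reaches the circulation, a higher number that a larger share of the oral dose reaches the circulation), compound 1 `Cn1c(=O)n(C)c2c(Oc3ccc(NC(=O)Nc4cc(C(C)(C)C)nn4-c4ccccc4)c(F)c3)ccnc21` gives 59%, the highest of the three numbers shown. For the measured compounds named here, compound 2 `Cc1ccc(-n2nc(C(C)(C)C)cc2NC(=O)Nc2ccc(Oc3ccnc4c3n(C)c(=O)n4C)cc2F)cc1` gives 31% in this assay, and the only single-point step recorded, a number 28 percentage points lower from compound 1 to compound 2 (beyond the scatter), lies beyond the scatter. Compound 3 `Cc1ccc(-n2nc(C(C)(C)C)cc2NC(=O)Nc2ccc(Oc3ccnc4[nH]c(=O)n(C)c34)cc2)cc1` gives 34%; it differs from compound 2 in two places at once, so its value is only noted next to that of compound 2, and the two sit within the scatter of each other.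

Compound 4 `CC(C)(C)c1cc(NC(=O)Nc2ccc(Oc3ccnc4[nH]c(=O)[nH]c34)cc2F)n(-c2ccccc2)n1` is reached from compound 1 by a group of 10 heavy atoms (6 carbon, 3 nitrogen, 1 oxygen; one five-membered aromatic ring with 2 hetero atoms, one six-membered aromatic ring with 1 hetero atom) in place of a group of 12 heavy atoms (8 carbon, 3 nitrogen, 1 oxygen; one five-membered aromatic ring with 2 hetero atoms, one six-membered aromatic ring with 1 hetero atom), on an oxygen on an aromatic ring. Going by the values given here, no measured step follows this change: the one step on record concerns the aryl methyl of compound 2 rather than the shared core. The pair of compound 2 and compound 3, where one ring methyl is also absent, shows no difference beyond the scatter, but the second change in that pair clouds any reading. He therefore expects only a moderate move downward for compound 4, and with wide uncertainty, the step being a number 15 percentage points lower from compound 1 to compound 4 (beyond the scatter). For compound 4 the estimate in this assay is 44%, within a range from 20% to 68%.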

Compound 4, oral bioavailability: 24%
The estimate for compound 4 lay 20 percentage points above the measured number; measured number inside the range.
By their numbers in this assay, from the lowest: compounds 4, 2 and 3 (each within the scatter of the next); then compound 1.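

For the compounds shown here, the change on an oxygen on an aromatic ring, where a group of 10 heavy atoms with 2 hydrogen-bond donors replaces a group of 12 heavy atoms with 0 hydrogen-bond donors, gives the first direct reading on the shared core in this assay. It yields a number 35 percentage points lower from compound 1 to compound 4 (beyond the scatter), a large step that shows the oral share is sensitive to this group and not only to the aryl methyl of the earlier step. Both single changes made to compound 1 so far lower the number beyond the scatter, and neither matches the value of compound 1, though these two changes sit in different places, and no measurement shown here explains the drop at this position.

The compounds shown leave open whether this step belongs to the two methyl groups lost together or mainly to one of them. They also leave open how the oral share in this assay would respond if an ethyl group, a longer chain or a methoxyethyl chain stood in place of those methyl groups within the group on an oxygen on an aromatic ring.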